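Methyl to Methoxy: One Small Change on a Shared Core

A few compounds are considered here, and "the series" means these few. Any claim that something is new, unique, unknown or untested is made for them only; others in the source may bear on it.

Of the compounds shown here, three built on one shared core have been tested in a functional assay on PC-3 cells (Homo sapiens) for antiproliferative activity, read by MTT assay, with a stated time of 48 h; on this read-out higher numbers stand for weaker inhibition and lower numbers for stronger inhibition. Compound 1 `O=C1c2ccc(F)cc2C(=O)N1c1nc(-c2ccccc2)cs1` gives 40200 nM. Compound 2 `O=C1c2ccc(F)cc2C(=O)N1c1nc(-c2ccc(F)cc2)cs1`, which carries fluoro in place of hydrogen, gives 39500 nM. Compound 3 `Cc1ccc(-c2csc(N3C(=O)c4ccc(F)cc4C3=O)n2)cc1`, which carries methyl in the same place, gives 44400 nM. These three numbers sit close together: compound 3 has the highest of the three, but its distances to compound 1 and to compound 2 both lie within the usual scatter, so none of the three can be called more or less active than another on these numbers.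

Compound 4 `COc1ccc(-c2csc(N3C(=O)c4ccc(F)cc4C3=O)n2)cc1` has not yet been measured. It differs from compound 3 in one place: methoxy in place of methyl on an aromatic carbon. The measured steps that bear on this change are a 1.1-fold higher number from compound 1 to compound 3 (0.04 log units; within the scatter) and a 1.1-fold higher number from compound 2 to compound 3 (0.05 log units; within the scatter), together with a 1.0-fold lower number from compound 1 to compound 2 (0.01 log units; within the scatter). Each of these swaps in the same place left the number essentially unmoved. On that basis the step expected in this assay is a 1.1-fold lower number from compound 3 to compound 4 (0.02 log units; within the scatter), which means no movement beyond the scatter. Compound 4 is therefore expected to give about 42000 nM, with a plausible range from 20000 nM to 90000 nM, kept wide since methoxy has not been tried in this set before.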

Compound 4, half-maximal inhibitory concentration: 41300 nM
Compound 4: the middle estimate sits 1.0-fold (0.01 log units) above what was measured, within the range that was stated.
By their numbers in this assay, from the lowest: compounds 2, 1, 4 and 3 (each within the scatter of the next).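

In this assay, methoxy brings an oxygen and a hydrogen-bond acceptor to this position for the first time among these compounds, yet the number stays put (a 1.1-fold lower number from compound 3 to compound 4 (0.03 log units; within the scatter)), and the comparisons with the fluoro and unsubstituted compounds read the same way (a 1.0-fold higher number from compound 2 to compound 4 (0.02 log units; within the scatter); a 1.0-fold higher number from compound 1 to compound 4 (0.01 log units; within the scatter)). Hydrogen, fluoro, methyl and methoxy now all give numbers within the scatter of one another, so the flat picture from the first three compounds also holds for a group with more heavy atoms than methyl and with a different kind of atom attached to the aromatic ring. No supporting measurement is available to explain this flat result.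

From the compounds shown here alone, it remains open whether a group of another kind at this position, such as an amine, a carboxylic acid or a longer chain like butoxy, would move the number beyond the scatter. All four compounds also share the rest of the core, so they cannot show whether a change elsewhere on it would matter more than the changes at this position.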